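The compounds below may be only part of what the source reports. "The series", "measured", "known", "first", "only" and "open" are said of these compounds alone.

Compound 1 `COc1cc(O)c2c(c1)O[C@H](c1ccc(O)cc1)C/C2=N\N`: >= 11300 nM, a limit
Compound 2 `COc1cc(O)c2c(c1)O[C@H](c1ccc(O)cc1)C/C2=N\Nc1ccccc1`: >= 11300 nM, a limit
Compound 3 `COc1ccc([C@@H]2C/C(=N\N)c3c(O)cc(OC)cc3O2)cc1`: >= 11300 nM, a limit

In a functional assay on L5178Y cells (Mus musculus) for inhibition, read by MTT assay, with a stated time of 24 h (a higher number here means a weaker inhibitor, a lower number a stronger inhibitor), compound 3 gives >= 11300 nM, which is a limit and not a number. For the measured compounds named here, it has company there, for the series so far shows only (the limit of >= 11300 nM in this assay, at which 3 of the 3 values shown sit). Compound 4 `COc1ccc([C@@H]2C/C(=N\Nc3ccccc3)c3c(O)cc(OC)cc3O2)cc1` is compound 3 with a single change: phenyl in place of hydrogen on an amine nitrogen. The same phenyl in place of hydrogen on an amine nitrogen has already been measured once, in a step that the two limits leave unreadable from compound 1 to compound 2. Going by the values given here, that pair is the closest precedent, yet it gives no size to carry over. The other measured change, methyl in place of hydrogen on an oxygen on an aromatic ring, is a step that the two limits leave unreadable from compound 1 to compound 3, and it too gives no size. Compound 3 carries that methyl, so compound 4 combines the two changes, and neither has yet moved a compound off the limit in this assay. No step beyond the scatter is therefore expected, in either direction, and the most likely outcome is another limit. The estimated change is a step that the limit leaves unreadable from compound 3 to compound 4. For compound 4 the expected value is 14000 nM, with an estimated range from 6000 nM to 30000 nM.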

Compound 4, half-maximal inhibitory concentration: >= 11300 nM
Compound 4 ended at the assay's limit (the forecaster's own chance of this, stated with the estimate: 75%); the middle value lies beyond the limit too.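

In this assay compound 4 gives >= 11300 nM, which is a limit and not a number. Its steps from compound 2 and from compound 3 cannot be read, and the series stands as before: the limit of >= 11300 nM in this assay, at which 4 of the 4 values shown sit.

The compounds shown leave open how far each lies past that limit, and whether either the phenyl or the methyl changes the read-out at all.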